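2-Phenylethenyl in place of phenyl: cytotoxicity outlook

This account rests on a few compounds, and the source may have more. Where it says the series, first, only, none or still open, it means among the compounds named here.

Compound 1 `CC(=O)c1cc(-c2ccccc2)cc2cc(-c3ccc(F)cc3)[nH]c12` is known only as a limit: in a functional assay on HeLa cells (Homo sapiens) for cytotoxicity, read by MTT assay, with a stated time of 2 days (on this read-out higher numbers stand for lower toxicity in this test and lower numbers for higher toxicity in this test), compound 1 gives > 100000 nM, as the limit of > 100000 nM in this assay, at which 1 of the 2 values shown sits, records. Compound 2 `COc1ccc(-c2cc3cc(-c4ccccc4)cc(C(C)=O)c3[nH]2)cc1` gives 18900 nM in this assay. For the measured compounds named here, the single measured step, an at least 5.2-fold lower number from compound 1 to compound 2 (0.72 log units; beyond the scatter), touches a different position and does not bear on the change now considered. Compound 3 `CC(=O)c1cc(/C=C/c2ccccc2)cc2cc(-c3ccc(F)cc3)[nH]c12` carries 2-phenylethenyl in place of phenyl on an aromatic carbon. Going by the values given here, with no measured step covering this change, no shift beyond the scatter is expected in this assay, and a further limit remains plausible. For compound 3 the estimate is 70000 nM (range 15000 nM to 200000 nM), an expected step of an at least 1.4-fold lower number from compound 1 to compound 3 (0.15 log units; that floor lies within the scatter).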

Compound 3, concentration lethal to 50% of the cells: 16100 nM
The estimate for compound 3 lay 4.3-fold (0.64 log units) above the measured number, within the range that was stated.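

At the aromatic carbon meta to the acetyl group, 2-phenylethenyl in place of phenyl gives an at least 6.2-fold lower number from compound 1 to compound 3 (0.79 log units; beyond the scatter) in this assay. For the compounds shown here, the earlier compounds kept phenyl fixed here, so this is the first sign that the number responds to a change at this position. The size of the step is only a floor, since the value for compound 1 is a limit: the limit of > 100000 nM in this assay, at which 1 of the 3 values shown sits.

From the compounds shown here alone, whether 2-phenylethyl, which lacks the double bond, or an amine at this position would shift the number stays open. So does the outcome of pairing 2-phenylethenyl with methoxy in place of fluoro.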